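A few compounds are considered here, and "the series" means these few. Any claim that something is new, unique, unknown or untested is made for them only; others in the source may bear on it.

Measured so far:
compound 1 `Cc1cc(-c2nc3sc(C)cn3c2/C=N/NC(=N)N)c(C)s1` — 4470 nM
compound 2 `Cc1cn2c(/C=N/NC(=N)N)c(-c3cccs3)nc2s1` — 5750 nM
compound 3 `Cc1cc(-c2nc3n(c2/C=N/NC(=N)N)CCS3)c(C)s1` — 24000 nM

All three were tested in a functional assay on cells (Cancer cell lines, Homo sapiens) for inhibition; on this read-out higher numbers stand for weaker inhibition of growth and lower numbers for stronger inhibition of growth. Compound 1 and compound 2 share one core, and the change between them is thiophen-2-yl in place of 2,5-dimethylthiophen-3-yl on an aromatic carbon. That step gave a 1.3-fold higher number from compound 1 to compound 2 (0.11 log units; within the scatter). Compound 3 carries a different core; how its core differs from that of compound 1 is not broken down here, but in this assay compound 3 gives the highest of the three numbers, well beyond the scatter from both others.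

Compound 4 `N=C(N)N/N=C/c1c(-c2cccs2)nc2n1CCS2` is not yet measured. It differs from compound 3 by thiophen-2-yl in place of 2,5-dimethylthiophen-3-yl on an aromatic carbon. The surroundings of the place are not identical: here the carbon is also two ring bonds from two ring atoms that each bear a fused ring, so this is the same kind of change, not the same change. Because the earlier step of a 1.3-fold higher number from compound 1 to compound 2 (0.11 log units; within the scatter) stayed within the scatter, the step for compound 4 is expected to be a 1.3-fold higher number from compound 3 to compound 4 (0.10 log units; within the scatter). Compound 4 is therefore estimated at 30000 nM, between 12000 nM and 75000 nM.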

Compound 4, concentration for 50% growth inhibition: 17400 nM
Beside the measured number, compound 4's estimate is 1.7-fold (0.24 log units) above it; the measured number falls inside the stated range.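

Replacing 2,5-dimethylthiophen-3-yl with thiophen-2-yl gives, in this assay, a 1.4-fold lower number from compound 3 to compound 4 (0.14 log units; within the scatter). Set beside the earlier step, the same change cannot be told apart on the two cores: the same change on two cores in this assay, a 1.3-fold higher number (0.11 log units; within the scatter) from compound 1 to compound 2 and a 1.4-fold lower number (0.14 log units; within the scatter) from compound 3 to compound 4, 1.8-fold (0.25 log units) apart, within the scatter of two such steps. This shows that the swap leaves no readable mark on either core, but both steps are too small to show a shared direction, and two cores say nothing about any other core.

Going by these compounds, both groups at this place are thiophenes, so the effect of a quite different group there, such as an amine, a carboxylic acid or a longer alkyl chain, remains open. On these data alone, it also remains open whether such a group would act alike on both cores.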